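The source may report more compounds than this note shows. Statements on the series, on what has been measured and on what is new or still open speak of the compounds shown alone.

In a functional assay on NCI-H1581 cells (Homo sapiens) for antiproliferative activity, read by CCK-8 assay, with a stated time of 72 h (on this read-out lower numbers stand for stronger inhibition and higher numbers for weaker inhibition), compound 1 (`COc1cc(OC)c(Cl)c(-c2ccc3c(NC(=O)c4ccc(N5CCN(C)CC5)cc4)n[nH]c3n2)c1Cl`) reads 1.7 nM. Compound 3 (`COc1cc(OC)c(Cl)c(-c2ccc3c(NC(=O)c4ccc(N5CCCN(C)CC5)cc4)n[nH]c3n2)c1Cl`) reads 1.3 nM, which is a 1.3-fold lower number from compound 1 to compound 3 (0.12 log units; within the scatter), so the two cannot be separated. Compound 2 (`COc1cc(OC)c(Cl)c(-c2ccc3c(NC(=O)c4ccc(N5CCCCC5)cc4)n[nH]c3n2)c1Cl`) reads 558 nM, which is a 330-fold higher number from compound 1 to compound 2 (2.52 log units; beyond the scatter), and a 430-fold lower number from compound 2 to compound 3 (2.63 log units; beyond the scatter) is also large. Compound 4 (`COc1cc(OC)c(Cl)c(-c2ccc3c(NC(=O)c4ccc(N5CCN(C)CC5)cc4Cl)n[nH]c3n2)c1Cl`) differs from compound 1 by chloro in place of hydrogen on an aromatic carbon, with chloro in place of hydrogen on an aromatic carbon, ortho to a large group and meta to a 4-methylpiperazin-1-yl group. For the measured compounds named here, the measured steps exchange only that 4-methylpiperazin-1-yl group, so they bear on this change indirectly at best. A modest rise in this assay is expected from the starting point of compound 1 at 1.7 nM, and the expected step is a 2.9-fold higher number from compound 1 to compound 4 (0.47 log units; beyond the scatter). Compound 4 is estimated at 5 nM, within an expected range of 1 nM to 40 nM.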

Compound 4, half-maximal inhibitory concentration: 27.6 nM
Compound 4: the middle estimate sits 5.5-fold (0.74 log units) below what was measured; the range from low to high includes it.
By their numbers in this assay, from the lowest: compounds 3 and 1 (each within the scatter of the next); then compound 4; then compound 2.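

Until now only the 4-methylpiperazin-1-yl group had been exchanged; compound 4 shows that this assay also responds to a change elsewhere on this six-membered aromatic ring. Chloro in place of hydrogen, ortho to a large group and meta to a 4-methylpiperazin-1-yl group, gives a 16-fold higher number from compound 1 to compound 4 (1.21 log units; beyond the scatter), so adding one chlorine here is enough for a large step. Nothing measured here accounts for this step.

On these data alone, whether fluoro, methyl or methoxy at this place would give a step of similar size remains open. So does whether chloro would act alike alongside the 4-methyl-1,4-diazepan-1-yl group of compound 3.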